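This account rests on a few compounds, and the source may have more. Where it says the series, first, only, none or still open, it means among the compounds named here.

Among the measured compounds shown here, in a functional assay on WM793 cells (Homo sapiens) for antiproliferative activity, read by MTT assay, with a stated time of 72 h (a higher number here means a weaker inhibitor of growth, a lower number a stronger inhibitor of growth), compound 1 `Cc1ccc(-n2nnc(C(=O)Nc3ccc(SC#N)cc3)c2C)cc1C` gives 72400 nM and compound 2 `Cc1ccc(Cl)cc1-n1nnc(C(=O)Nc2ccc(SC#N)cc2)c1C` gives 72800 nM, so compound 2 stands level with the only other measured compound. Compound 3 `COc1cccc(-n2nnc(C(=O)Nc3ccc(SC#N)cc3)c2C)c1` keeps the shared core and carries 3-methoxyphenyl in place of 5-chloro-2-methylphenyl on an aromatic nitrogen. For the measured compounds named here, no measured compound bears 3-methoxyphenyl. Going by the values given here, the one measured change at this place, a 1.0-fold higher number from compound 1 to compound 2 (0.00 log units; within the scatter), stayed within the scatter, so no step beyond the scatter is expected in this assay, in either direction. The expected step is a 1.2-fold lower number from compound 2 to compound 3 (0.07 log units; within the scatter). For compound 3 the estimate is 62000 nM, with an expected range of 28000 nM to 120000 nM.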

Compound 3, concentration for 50% growth inhibition: > 100000 nM
Compound 3: a limit, no number; the forecaster's own chance of this, stated with the estimate: 15%; middle value at least 1.6-fold (0.20 log units) away from the limit.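

In this assay compound 3 gives a limit and not a number: the limit of > 100000 nM in this assay, at which 1 of the 3 values shown sits.

The steps read an at least 1.3-fold higher number from compound 2 to compound 3 (0.13 log units; that floor lies within the scatter) and an at least 1.3-fold higher number from compound 1 to compound 3 (0.14 log units; that floor lies within the scatter), so their true size cannot be read, and neither floor goes beyond the scatter. Still, 3-methoxyphenyl, which carries a hydrogen-bond acceptor where 5-chloro-2-methylphenyl carries none, gives no lower number at this place on the aromatic nitrogen.

As far as these compounds go, how far compound 3 lies past its limit stays open. So does whether an amine or a carboxylic acid on this phenyl ring would give a lower number.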